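Stretching the chain and swapping the amine substituent

A few compounds are considered here, and "the series" means these few. Any claim that something is new, unique, unknown or untested is made for them only; others in the source may bear on it.

Measured so far, in a functional assay on the whole organism for inhibition, with Mus musculus as the target; a higher number here means that more compound is needed for the effect, a lower number that less compound is needed:
Compound 1 `CC(C)NCC(=O)Nc1cccc2c1CN(C)CC2c1ccccc1` gives 14 mg/kg.
Compound 2 `CCCCNCC(=O)Nc1cccc2c1CN(C)CC2c1ccccc1` gives 32 mg/kg.
Compound 3 `CC(C)NCCC(=O)Nc1cccc2c1CN(C)CC2c1ccccc1` gives 150 mg/kg.

Compound 1 and compound 2 differ in one place, (butyl in place of isopropyl on an amine nitrogen), and this change made the step of a 2.3-fold higher number from compound 1 to compound 2 (0.36 log units; beyond the scatter). Compound 3 differs from compound 1 in its core, ((isopropylamino)methyl in place of isopropylamino on a saturated chain carbon bound to a carbonyl carbon), which brought the step of an 11-fold higher number from compound 1 to compound 3 (1.03 log units; beyond the scatter); against compound 2 the step is a 4.7-fold higher number from compound 2 to compound 3 (0.67 log units; beyond the scatter).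

Compound 4 `CCCCNCCC(=O)Nc1cccc2c1CN(C)CC2c1ccccc1` has not yet been measured in this assay. It carries the same change relative to compound 3, (butyl in place of isopropyl on an amine nitrogen), and the place is the same in words for both pairs, so this is the same change on a different core. Starting from compound 3, a step like a 2.3-fold higher number from compound 1 to compound 2 (0.36 log units; beyond the scatter) is expected, giving a 2.3-fold higher number from compound 3 to compound 4 (0.36 log units; beyond the scatter), because a 2.3-fold higher number from compound 1 to compound 2 (0.36 log units; beyond the scatter) is the only measured instance of this change; with one example and a different core, the range is kept wide. Compound 4 is thus expected at 340 mg/kg, between 150 mg/kg and 800 mg/kg.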

Compound 4, dose for half-maximal effect: about 46 mg/kg
Compound 4: middle estimate off by 7.4-fold (0.87 log units), on the high side; the measured number lies below the stated range.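

In this assay, butyl in place of isopropyl on the amine nitrogen does not carry over from one core to the other, and its direction reverses: the same change on two cores in this assay, a 2.3-fold higher number (0.36 log units; beyond the scatter) from compound 1 to compound 2 and a 3.3-fold lower number (0.51 log units; beyond the scatter) from compound 3 to compound 4, 7.5-fold (0.87 log units) apart, beyond the scatter of two such steps On the core of compound 3 the change gives a 3.3-fold lower number from compound 3 to compound 4 (0.51 log units; beyond the scatter), while (butylamino)methyl in place of butylamino leaves a 1.4-fold higher number from compound 2 to compound 4 (0.16 log units; within the scatter), within the scatter, and (butylamino)methyl in place of isopropylamino gives a 3.3-fold higher number from compound 1 to compound 4 (0.52 log units; beyond the scatter). So the effect of this amine substituent depends on the core it sits on, but with a single pair on each core this shows neither why the direction reverses nor what the change would do on any further core.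

The compounds shown leave open how other groups on the amine nitrogen, such as tert-butyl or cyclohexyl, would behave on these two cores. They also leave open whether a still longer chain on the carbonyl carbon would follow compound 3 or compound 4.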